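A few compounds are considered here, and "the series" means these few. Any claim that something is new, unique, unknown or untested is made for them only; others in the source may bear on it.

Among the measured compounds shown here, in a physicochemical assay for lipophilicity (a higher number here means a more lipophilic compound, a lower number a more polar compound), two compounds on a shared core have numbers so far. Compound 1 (`C[C@H]1CC[C@@H]2[C@@H](OC(=O)[C@]23CC(c2ccc(N(C)C)cc2)=NO3)[C@]2(C)C(=O)C=C[C@@]12O`) gives 1.51 and compound 2 (`Cc1cccc(C2=NO[C@]3(C2)C(=O)O[C@@H]2[C@H]3CC[C@H](C)[C@]3(O)C=CC(=O)[C@@]23C)c1`) gives 1.86 in the same measurement, so compound 2 stands the higher of the two, beyond the scatter. Compound 3 (`C[C@H]1CC[C@@H]2[C@@H](OC(=O)[C@]23CC(c2ccc(C#N)cc2)=NO3)[C@]2(C)C(=O)C=C[C@@]12O`) has yet to be measured. It departs from compound 2 at one place: 4-cyanophenyl in place of 3-methylphenyl on a carbon with a double bond to nitrogen on a carbon with a double bond to nitrogen of a five-membered non-aromatic ring with 1 nitrogen and 1 oxygen. For the measured compounds named here, only one measured step bears on this place, a number 0.35 log units higher from compound 1 to compound 2 (beyond the scatter) at the same carbon. That step is modest and involves a different pair of groups, so it offers a scale and no more. Since 3-methylphenyl, the group that leaves, sits on the higher of the two compounds, a downward step of similar or somewhat larger size is expected in this assay. In numbers, the expected change is a number 0.66 log units lower from compound 2 to compound 3 (beyond the scatter) in this estimate. The estimate for compound 3 is 1.2 within an expected range from 0.8 to 1.6 as the likely span.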

Compound 3, partition coefficient: 1.17
For compound 3 the middle estimate is 0.03 log units above the measured one; low and high end bracket the measured number.
By their numbers in this assay, from the lowest: compound 3; then compound 1; then compound 2.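

In this assay, replacing 3-methylphenyl with 4-cyanophenyl on the carbon with a double bond to nitrogen gives a number 0.69 log units lower from compound 2 to compound 3 (beyond the scatter), which shows that this position can carry the number below that of compound 1, the lowest seen before. Compound 3 also allows a comparison the earlier pair could not. It keeps the substituent at the 4-position of the phenyl: cyano in place of dimethylamino gives a number 0.34 log units lower from compound 1 to compound 3 (beyond the scatter), so changing the group alone, with its printed ring position unchanged, moves the number beyond the scatter. Nothing measured here accounts for the size or direction of either step.

The step from compound 2 to compound 3 changes both the substituent and its printed ring position, so its two parts cannot be separated, and a 4-methylphenyl group would be needed to tell them apart. As far as these compounds go, an unsubstituted phenyl group would give these three compounds a common reference, and it remains open whether a carboxylic acid or a longer alkyl chain at the 4-position would extend the range seen so far.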